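Methoxy to trifluoromethyl on the pendant aryl amine

The source may hold more compounds than are shown below. What is called first, only, known or untested is meant among the compounds shown, and "the series" means these compounds.

Measured in a functional assay on MDA-MB-231 cells (Homo sapiens) for antiproliferative activity, read by MTT assay, with a stated time of 72 h; on this read-out higher numbers stand for weaker inhibition and lower numbers for stronger inhibition:
compound 1 `O=S1(=O)C=Cc2cccc(Nc3ccc(C(F)(F)F)cc3)c21` gives 1200 nM
compound 2 `COc1ccc(Nc2cccc3c2S(=O)(=O)C=C3)cc1` gives 1040 nM
compound 3 `COc1ccccc1Nc1cccc2c1S(=O)(=O)C=C2` gives 2400 nM

Compound 3 and compound 2 have the same atoms joined differently; the difference between the two cores is not broken down here. Compound 4 `O=S1(=O)C=Cc2cccc(Nc3ccccc3C(F)(F)F)c21` is not yet measured in this assay. It arises from compound 3 by trifluoromethyl in place of methoxy on an aromatic carbon. The same kind of change links compound 2 to compound 1, (trifluoromethyl in place of methoxy on an aromatic carbon), but there the entering group sits para to a large group, whereas in compound 4 it sits ortho to a large group. That earlier step in this assay was a 1.2-fold higher number from compound 2 to compound 1 (0.06 log units; within the scatter). The expectation for compound 4 rests on that step, so an estimated step of a 1.2-fold higher number from compound 3 to compound 4 (0.07 log units; within the scatter) is taken, with added uncertainty for the ortho placement. Compound 4 is therefore expected near 2800 nM, between 1200 nM and 6500 nM.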

Compound 4, half-maximal inhibitory concentration: 3900 nM
Compound 4: the middle estimate sits 1.4-fold (0.14 log units) below what was measured; the range from low to high includes it.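

In this assay, trifluoromethyl in place of methoxy gives a 1.6-fold higher number from compound 3 to compound 4 (0.21 log units; within the scatter), and the same change agrees across the two cores: the same change on two cores in this assay, a 1.2-fold higher number (0.06 log units; within the scatter) from compound 2 to compound 1 and a 1.6-fold higher number (0.21 log units; within the scatter) from compound 3 to compound 4, 1.4-fold (0.15 log units) apart, within the scatter of two such steps.
On these two cores, the change therefore leaves the number within the scatter, including where the entering group sits ortho to a large group. This rests on two pairs only, and since neither step lies beyond the scatter, it shows no carrying over of a sizeable effect and says nothing about a third core.

Still open, going by these compounds, is how a nitrile or a carboxylic acid would compare with methoxy and trifluoromethyl at these places on the pendant ring. On these data alone, a replacement of the amine linking that ring to the core also remains open.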